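The source may hold more compounds than are shown below. What is called first, only, known or untested is meant among the compounds shown, and "the series" means these compounds.

Measured in a functional assay on CHO cells with adenosine receptor A1 (Homo sapiens) as the target, read by cAMP accumulation and immunoassay, with a stated time of 6 min, tested at 0.1 uM; a higher number here means a weaker effect of the compound at the concentration tested, a lower number a stronger effect:
compound 1, `Nc1scc(CN2CCN(c3ccc(Cl)cc3Cl)CC2)c1C(=O)c1ccc(Cl)cc1`: -11%
compound 2, `COc1ccc(N2CCN(Cc3csc(N)c3C(=O)c3ccc(Cl)cc3)CC2)cc1`: 0%
compound 3, `Nc1scc(CN2CCN(c3ccccc3C(F)(F)F)CC2)c1C(=O)c1ccc(Cl)cc1`: -7.5%

Going by the values given here, compound 2 has the highest number of the three, though only one of its two steps is beyond the scatter: a number 11 percentage points higher from compound 1 to compound 2 (beyond the scatter), whereas a number 7.5 percentage points lower from compound 2 to compound 3 (within the scatter) stays within it. Compound 4, `Nc1scc(CN2CCN(c3cccnc3)CC2)c1C(=O)c1ccc(Cl)cc1`, differs from compound 2 in one place: pyridin-3-yl in place of 4-methoxyphenyl on an amine nitrogen in a ring. Both measured steps bear on this swap, since each also exchanges the group on the same ring nitrogen, and one was modest while the other was within the scatter. The three numbers all sit near zero, so no step beyond the scatter is expected here; the expected step is a number 3 percentage points lower from compound 2 to compound 4 (within the scatter). Compound 4 is estimated at -3%, between -15% and 9%.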

Compound 4, a percentage reported as activity, at one concentration (the size of the read-out at that concentration, not a potency): 3.4%
Compound 4: middle estimate off by 6.4 percentage points, on the low side; the measured number falls inside the stated range.
By their numbers in this assay, from the lowest: compounds 1, 3, 2 and 4 (each within the scatter of the next, the first and the last beyond it).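

In this assay, going by these compounds alone, pyridin-3-yl, the only group here with a hetero atom in its aromatic ring, gives a number 3.4 percentage points higher from compound 2 to compound 4 (within the scatter) relative to 4-methoxyphenyl, so the two cannot be told apart. Beyond the scatter, however, lie a number 10.9 percentage points higher from compound 3 to compound 4 (beyond the scatter) and a number 14.4 percentage points higher from compound 1 to compound 4 (beyond the scatter), both modest, so this ring nitrogen tolerates changes that shift the read-out only slightly. Still open, going by these compounds, is whether a saturated group such as cyclohexyl, or a benzyl group, at this place would move the read-out further from zero. No measured evidence accounts for these steps.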